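The source may report more compounds than this note shows. Statements on the series, on what has been measured and on what is new or still open speak of the compounds shown alone.

Working notes on the series. For the measured compounds named here, in a physicochemical assay for acid dissociation, compound 1 (`O=S(=O)(Nc1ccccc1)c1ccccc1`) gives 9.1, the higher of the two numbers so far. Compound 2 (`O=S(=O)(Nc1ccccc1)c1ccc(Br)cc1`) gives 8.5.

The next structure is compound 3 (`Cc1ccc(NS(=O)(=O)c2ccccc2)cc1`), which keeps the core of compound 1 and carries one change: methyl in place of hydrogen on an aromatic carbon. In words, this is methyl in place of hydrogen on an aromatic carbon, para to a large group.

Going by the values given here, only one measured step bears on this change: a number 0.60 log units lower from compound 1 to compound 2 (beyond the scatter). It is also a replacement of hydrogen on an aromatic carbon, but the entering group is bromo rather than methyl. It therefore gives a rough scale for a single replacement on this core, not a direct precedent. Among the compounds with values here, no methyl step has been measured in this assay.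

A small rise is expected, smaller in size than the bromo step and opposite in direction, though it may not clear the scatter. The expected change is a number 0.30 log units higher from compound 1 to compound 3 (within the scatter). For compound 3 the estimated value is 9.4, with an expected range from 9.1 to 9.7.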

Compound 3, acid dissociation constant: 9.34
Estimate against measurement, compound 3: 0.06 log units above; measured number inside the range.
By their numbers in this assay, from the lowest: compound 2; then compounds 1 and 3 (each within the scatter of the next).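

In this assay, methyl in place of hydrogen on an aromatic carbon, para to a large group, gives a number 0.24 log units higher from compound 1 to compound 3 (within the scatter) and thus no readable separation from the parent. A single replacement on an aromatic carbon of the shared core therefore does not always produce a readable step: a number 0.60 log units lower from compound 1 to compound 2 (beyond the scatter) stands beyond the scatter, whereas the methyl step does not. That contrast involves a different entering group at a different site, so it cannot be assigned to the group or to the site alone, and no measurement is available to explain the result.

As far as these compounds go, it remains open whether an amine, a carboxylic acid or a longer chain such as propyl, placed where the methyl sits in compound 3, would give a step beyond the scatter, and in which direction. Also open, from the compounds shown here alone, is what bromo would give at that same place, which would separate the effect of the entering group from that of the site.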